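Swapping tert-butyl for trifluoromethyl on a hydroxamic acid inhibitor

The source may hold more compounds than are shown below. What is called first, only, known or untested is meant among the compounds shown, and "the series" means these compounds.

Measured so far:
compound 1, `O=C(NO)c1ccc(N(Cc2ccc(C(F)(F)F)cc2)C(=O)CN(Cc2ccccc2C(F)(F)F)S(=O)(=O)c2ccc(F)cc2)cc1`, 304 nM
compound 2, `CC(C)(C)c1ccc(CN(C(=O)CN(Cc2c(F)c(F)c(F)c(F)c2F)S(=O)(=O)c2ccc(F)cc2)c2ccc(C(=O)NO)cc2)cc1`, 636 nM

Both compounds share a core that carries a hydroxamic acid, and both were tested in an assay on Sf9 cells for inhibition of histone deacetylase 11 (Homo sapiens), read by mobility shift assay; on this read-out higher numbers stand for weaker inhibition and lower numbers for stronger inhibition. Compound 1 gives 304 nM, and compound 2 gives 636 nM, so compound 2 stands at the higher, weaker end of the two numbers, a gap that lies beyond the usual scatter.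

Compound 3, `O=C(NO)c1ccc(N(Cc2ccc(C(F)(F)F)cc2)C(=O)CN(Cc2c(F)c(F)c(F)c(F)c2F)S(=O)(=O)c2ccc(F)cc2)cc1`, has not been measured yet. It differs from compound 2 in a single spot: trifluoromethyl in place of tert-butyl on an aromatic carbon. The group that enters is the same group that compound 1 carries in that position, while the rest of compound 3 matches compound 2. Going by the values given here, with no directly comparable step available, the expectation for the move from compound 2 to compound 3 is a modest shift towards stronger inhibition, a 1.5-fold lower number from compound 2 to compound 3 (0.18 log units; within the scatter), though one that might not exceed the scatter. On that basis compound 3 is estimated at 420 nM, with a plausible range from 150 nM to 1200 nM.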

Compound 3, half-maximal inhibitory concentration: 191 nM
For compound 3 the middle estimate is 2.2-fold (0.34 log units) above the measured one; measured number inside the range.
By their numbers in this assay, from the lowest: compounds 3 and 1 (each within the scatter of the next); then compound 2.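

Putting 4-(trifluoromethyl)benzyl in place of 4-(tert-butyl)benzyl, with the rest of the molecule unchanged, gives in this assay a 3.3-fold lower number from compound 2 to compound 3 (0.52 log units; beyond the scatter) and so shows that this position responds to the swap by more than the usual scatter. The other one-place comparison, 2,3,4,5,6-pentafluorophenyl in place of 2-(trifluoromethyl)phenyl on the saturated chain carbon bound to the sulfonamide nitrogen, gives a 1.6-fold lower number from compound 1 to compound 3 (0.20 log units; within the scatter) and stays within the scatter, so those two groups cannot be told apart here. Nothing available explains either result.

The compounds shown leave open how a methyl group or a nitrile would compare with trifluoromethyl on that aromatic carbon. They also leave open whether the step from tert-butyl to trifluoromethyl would be the same size with 2-(trifluoromethyl)phenyl on the chain.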